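Cyclohexyl for isopropyl on the lactam nitrogen

A few compounds are considered here, and "the series" means these few. Any claim that something is new, unique, unknown or untested is made for them only; others in the source may bear on it.

Two compounds of the series have a number in an assay on HEK293 cells for positive allosteric modulation of metabotropic glutamate receptor 2 (Rattus norvegicus), read by thallium flux (on this read-out lower numbers stand for smaller maximal responses and higher numbers for larger maximal responses), so far. Compound 1 `CC(C)N1Cc2cc(OCc3cccc(-c4ccc(Cl)c(C(=O)O)c4)c3)ccc2C1=O` is the higher of the two: in this assay compound 1 gives 88.1%. Compound 2 `Cc1c(OCc2cccc(-c3ccc(Cl)c(C(=O)O)c3)c2)cc2c(c1C)C(=O)C(C1CCCC1)C2` carries a different core arrangement around the carbonyl, and in this assay compound 2 gives 77.3%, a gap to compound 1 that lies beyond the usual scatter of repeated measurements. Among the compounds with values here, no pair of measured compounds differs in a single place, so there is no measured step to lean on.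

Compound 3 `O=C(O)c1cc(-c2cccc(COc3ccc4c(c3)CN(C3CCCCC3)C4=O)c2)ccc1Cl` is not yet measured. It departs from compound 1 in one place: cyclohexyl in place of isopropyl on an amide-type nitrogen in a ring. The rest of the molecule, including the acid-bearing biaryl and the ether link, is unchanged.

Without a single-change comparison, the expectation is cautious. Both measured compounds reach a sizeable maximal response, and the change keeps the same kind of non-polar substituent on the same nitrogen, so the step from compound 1 to compound 3 is expected to be small and within the scatter, a number 3.1 percentage points lower from compound 1 to compound 3 (within the scatter). For compound 3 in this assay the estimated value is 85%, with a range from 70% to 100%.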

Compound 3, largest response reached (Emax), in percent of the reference or control that the assay uses: 63.3%
Compound 3: the middle estimate sits 21.7 percentage points above what was measured, and the stated range ends above it.
By their numbers in this assay, from the lowest: compound 3; then compound 2; then compound 1.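

Notes on the amide-type nitrogen: this is the first single change in the series that can be read, and in this assay cyclohexyl in place of isopropyl gives a number 24.8 percentage points lower from compound 1 to compound 3 (beyond the scatter), a step beyond the scatter. The maximal response is therefore sensitive to the group at this position, even with the rest of the molecule unchanged and with both groups made of carbon only, uncharged and without hydrogen-bond donors or acceptors. The difference lies in isopropyl with 3 heavy atoms and no ring against cyclohexyl with 6 heavy atoms and one six-membered non-aromatic ring, but no available measurement explains the step.

Going by these compounds, it remains open whether the lower response follows the ring or the carbon count, a question that cyclopropyl, cyclobutyl or an open chain such as n-butyl on the same nitrogen could help separate. Also open, on these data alone, are how methyl or tert-butyl at this position would compare with isopropyl, and whether a ring carrying oxygen, such as tetrahydropyranyl, would behave like cyclohexyl.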